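The source may report more compounds than this note shows. Statements on the series, on what has been measured and on what is new or still open speak of the compounds shown alone.

Measured compounds:
Compound 1 `O=C(CSc1nc(Nc2ccccc2)c2ccccc2n1)Nc1ccccc1F` gives 10700 nM in a functional assay on MGC-803 cells (Homo sapiens) for inhibition, read by MTT assay, with a stated time of 72 h; a lower number here means a stronger inhibitor, a higher number a weaker inhibitor.
Compound 2 `O=C(CSc1nc(Nc2ccccc2)c2ccccc2n1)Nc1cccc(Cl)c1` gives 14300 nM in this assay.
Compound 3 `C=CC(=O)Nc1cccc(NC(=O)CSc2nc(Nc3ccccc3)c3ccccc3n2)c1` gives 7310 nM in this assay.

Compound 3 has the lowest of the three numbers, but its gaps to the others are small: a 1.5-fold lower number from compound 1 to compound 3 (0.17 log units; within the scatter) and a 2.0-fold lower number from compound 2 to compound 3 (0.29 log units; within the scatter) both fall within the scatter, as does a 1.3-fold higher number from compound 1 to compound 2 (0.13 log units; within the scatter). So far, then, the three compounds cannot be told apart.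

Compound 4 `C=CC(=O)Nc1cccc(NC(=O)CSc2nc(Nc3ccc(F)cc3)c3ccccc3n2)c1` has not yet been measured. It differs from compound 3 by fluoro in place of hydrogen on an aromatic carbon; the anilino group becomes (4-fluorophenyl)amino. Going by the values given here, none of the measured steps touches this part of the molecule: all three vary the group on the amide-type nitrogen, and none of them moves the number beyond the scatter. Among the compounds with values here, there is therefore no direct precedent, and a small step is expected, in no clear direction.

Compound 4 is accordingly estimated at 6500 nM, with a range from 2500 nM to 16000 nM. The expected step is a 1.1-fold lower number from compound 3 to compound 4 (0.05 log units; within the scatter), within the scatter.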

Compound 4, half-maximal inhibitory concentration: 8290 nM
Compound 4: the middle estimate sits 1.3-fold (0.11 log units) below what was measured; low and high end bracket the measured number.
By their numbers in this assay, from the lowest: compounds 3, 4, 1 and 2 (each within the scatter of the next).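

Going by these compounds alone, compound 3 and compound 4 are the only pair here that differ on the anilino group rather than on the group at the amide-type nitrogen, and in this assay this fluoro for hydrogen exchange gives a 1.1-fold higher number from compound 3 to compound 4 (0.05 log units; within the scatter). This aromatic carbon, para to a large group, therefore accepts a single fluorine with no readable effect on the number, so this ring position joins the amide-nitrogen group in showing no step beyond the scatter. Nothing measured here speaks to why the fluorine makes so little difference.

From the compounds shown here alone, whether a larger or different group at this carbon, such as an amine, a methoxy group or a carboxylic acid, would move the number beyond the scatter remains open. Also open, going by these compounds, is whether fluoro would give the same small step with the 2-fluorophenyl or 3-chlorophenyl amide groups of compound 1 and compound 2.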